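Spiro-isoxazoline lactones: aryl changes and SW-620 cytotoxicity

The source may report more compounds than this note shows. Statements on the series, on what has been measured and on what is new or still open speak of the compounds shown alone.

Measured compounds in a functional assay on SW-620 cells (Homo sapiens) for cytotoxicity, read by sulforhodamine B assay, with a stated time of 48 h; a higher number here means a weaker inhibitor, a lower number a stronger inhibitor:
- compound 1 `C[C@H]1CC[C@@H]2[C@@H](OC(=O)[C@]23CC(c2c(Cl)cccc2Cl)=NO3)[C@]2(C)C(=O)C=C[C@@]12O` gives 43000 nM
- compound 2 `C[C@H]1CC[C@@H]2[C@@H](OC(=O)[C@]23CC(c2ccc(N(C)C)cc2)=NO3)[C@]2(C)C(=O)C=C[C@@]12O` gives 5100 nM
- compound 3 `Cc1ccc(C2=NO[C@]3(C2)C(=O)O[C@@H]2[C@H]3CC[C@H](C)[C@]3(O)C=CC(=O)[C@@]23C)cc1` gives 2500 nM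

Compound 2 stands second highest of the three numbers. Its nearest neighbour is compound 3, reached by a 2.0-fold lower number from compound 2 to compound 3 (0.31 log units; beyond the scatter); its furthest is compound 1, from which an 8.4-fold lower number from compound 1 to compound 2 (0.93 log units; beyond the scatter) leads to compound 2. Against the same starting point, a 17-fold lower number from compound 1 to compound 3 (1.24 log units; beyond the scatter) is the largest step in the set.

Compound 4 `C[C@H]1CC[C@@H]2[C@@H](OC(=O)[C@]23CC(c2ccc(F)cc2)=NO3)[C@]2(C)C(=O)C=C[C@@]12O` has not been measured. It differs from compound 2 by fluoro in place of dimethylamino on an aromatic carbon.

The step that bears most directly on this change is a 2.0-fold lower number from compound 2 to compound 3 (0.31 log units; beyond the scatter), where another small group replaced dimethylamino on the same aromatic carbon and gave a modest decrease. The steps from compound 1 show that single-ring aryl changes can move this assay by a modest to large amount, but both of those exchange 2,6-dichlorophenyl, not the group in question. Among the measured compounds shown here, no step with fluoro exists in the set.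

Compound 4 is therefore expected to land close to compound 2 or modestly lower, in the direction of compound 3: the estimated step is a 1.5-fold lower number from compound 2 to compound 4 (0.16 log units; within the scatter). The estimate for compound 4 in this assay is 3500 nM, with a range from 1200 nM to 10000 nM.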

Compound 4, half-maximal inhibitory concentration: 3600 nM
For compound 4 the middle estimate is 1.0-fold (0.01 log units) below the measured one, and the stated range covers the measured number.
By their numbers in this assay, from the lowest: compounds 3, 4 and 2 (each within the scatter of the next, the first and the last beyond it); then compound 1.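

In this assay, fluoro joins dimethylamino and methyl on this aromatic carbon with a 1.4-fold lower number from compound 2 to compound 4 (0.15 log units; within the scatter) and a 1.4-fold higher number from compound 3 to compound 4 (0.16 log units; within the scatter), so compound 4 lies within the scatter of both, although a 2.0-fold lower number from compound 2 to compound 3 (0.31 log units; beyond the scatter) had placed those two just beyond it. On these three compounds, the change from dimethylamino to fluoro, which takes the heavy-atom count from 3 to 1 and the hydrogen-bond acceptor count from 1 to 0, gives no readable shift in this read-out. With a 12-fold lower number from compound 1 to compound 4 (1.08 log units; beyond the scatter), 4-fluorophenyl also joins 4-(dimethylamino)phenyl and 4-methylphenyl in standing well apart from the 2,6-dichlorophenyl of compound 1, and no data at hand offer an explanation for either finding.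

The compounds shown leave open whether a carboxylic acid, a primary amine or a longer alkyl chain on the same aromatic carbon would also stay within the scatter of compound 4. They also leave open whether the gap to compound 1 follows from chlorine itself or from its placement, a question that 4-chlorophenyl and 2-chlorophenyl analogues would address.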